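A few compounds are considered here, and "the series" means these few. Any claim that something is new, unique, unknown or untested is made for them only; others in the source may bear on it.

Compound 1 `COc1ccccc1Nc1nc(-c2cccc(F)c2)nc2ccc(F)cc12` gives > 50000 nM (a limit)
Compound 2 `Oc1cccc(Nc2nc(-c3cccc(F)c3)nc3ccc(F)cc23)c1` gives > 50000 nM (a limit)
Compound 3 `Cc1ccc(Nc2nc(-c3cccc(F)c3)nc3ccc(F)cc23)cc1` gives > 50000 nM (a limit)

Each of these results comes from a functional assay on MDA-MB-231 cells (Homo sapiens) for cytotoxicity, read by MTT assay, with a stated time of 48 h (on this read-out lower numbers stand for stronger inhibition and higher numbers for weaker inhibition), and is a limit of the assay, not a number. Compound 3 stands with the other two at one shared limit (the limit of > 50000 nM in this assay, at which 3 of the 3 values shown sit). Compound 4 `Cc1ccccc1Nc1nc(-c2cccc(F)c2)nc2ccc(F)cc12` carries 2-methylphenyl in place of 4-methylphenyl on a nitrogen on an aromatic ring. The measured steps that bear on this change swap the same group: a step that the two limits leave unreadable from compound 1 to compound 3 and a step that the two limits leave unreadable from compound 2 to compound 3. Neither has a readable size, so no step beyond the scatter is expected in this assay, and no direction can be named. The estimated step is small (a number no higher from compound 3 to compound 4 (the limit leaves the size open)). Compound 4 is expected near 50000 nM, with an estimated range of 20000 nM to 100000 nM.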

Compound 4, half-maximal inhibitory concentration: > 50000 nM
Compound 4: a limit, no number (the forecaster's own chance of this, stated with the estimate: 80%); the middle value lies on the limit itself.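

No step can be read between compound 4 and compound 1, compound 2 or compound 3, since each result is a limit rather than a number: the limit of > 50000 nM in this assay, at which 4 of the 4 values shown sit.

Whether the groups on the nitrogen change the activity of these compounds at all stays open.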